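Removing a Fluoro Group from a Stable Fused-Ring Compound

The source may hold more compounds than are shown below. What is called first, only, known or untested is meant among the compounds shown, and "the series" means these compounds.

Among the measured compounds shown here, compound 2, `CCC(/C=C1\OC(=O)NC1=O)(CC)c1ccc(-c2ccc3cc(F)cc(F)c3c2)[nH]c1=O`, is one of three compounds measured in an ADME assay on microsomes from liver (Homo sapiens) for metabolic stability; a lower number here means that the compound disappears faster, a higher number that the compound lasts longer. In this assay compound 2 gives > 3 h, which is a limit of the assay and not a number. Compound 1, `C/C(=C1/OC(=O)NC1=O)C(c1ccc(-c2ccc3cccc(F)c3c2)[nH]c1=O)C(C)C`, also gives > 3 h in this assay, again a limit. Compound 3, `CC(C)C(c1ccc(-c2ccc3cccc(F)c3c2)[nH]c1=O)C1C(=O)NC(=O)N1C`, gives 0.375 h in this assay, and the step of an at least 8.0-fold lower number from compound 1 to compound 3 (0.90 log units; beyond the scatter) concerns the five-membered ring on the saturated chain carbon, not the fused ring system. Two of the three values thus sit at the limit of > 3 h in this assay, at which 2 of the 3 values shown sit.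

Compound 4, `CCC(/C=C1\OC(=O)NC1=O)(CC)c1ccc(-c2ccc3cccc(F)c3c2)[nH]c1=O`, differs from compound 2 by hydrogen in place of fluoro on an aromatic carbon. For the measured compounds named here, no measured step alters the fused ring system by itself, so none bears directly on this change. Compound 1, however, carries the same fused ring system with a single fluoro group as compound 4 and sits at the limit in this assay, so that pattern of substitution is consistent with a value at the limit. Compound 4 is consequently expected to remain at or near the limit, and the expected step that the limit leaves unreadable from compound 2 to compound 4 is not one beyond the scatter. The estimate for compound 4 in this assay is 3.5 h, between 2 h and 7 h.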

Compound 4, half-life: 0.948 h
For compound 4 the middle estimate is 3.7-fold (0.57 log units) above the measured one; measured number below the stated range.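

Hydrogen in place of fluoro on this aromatic carbon, part of a fused system of two rings and meta to a fluoro group, gives in this assay an at least 3.1-fold lower number from compound 2 to compound 4 (0.50 log units; beyond the scatter). The fused ring system is therefore not a silent part of these compounds: a change of one heavy atom there moves the half-life beyond the scatter, which the earlier compounds could not show, as their only readable step lay in the five-membered ring on the saturated chain carbon. Compound 2 gives > 3 h, which is a limit of the assay and not a number, so the full size of the step stays unknown, because its starting point is only a limit: the limit of > 3 h in this assay, at which 2 of the 4 values shown sit.

The compounds shown leave open whether chloro, methyl or methoxy on this aromatic carbon would hold the half-life as fluoro does in compound 2, or whether only fluoro does so. They also leave open what removing the remaining fluoro group would do, and whether the same exchange would give a step of like size with another chain on the shared core.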